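The source may report more compounds than this note shows. Statements on the series, on what has been measured and on what is new or still open speak of the compounds shown alone.

Measured in an ADME assay on HEK-293T cells (Homo sapiens) for cytotoxicity, read by MTT assay, with a stated time of 72 h; a lower number here means a stronger inhibitor, a higher number a weaker inhibitor:
Compound 1 `O=C(Nc1nc2ccccc2s1)c1cn(-c2ccccc2)nc1-c1ccccc1`: > 50000 nM
Compound 2 `O=C(Nc1nc2ccc(F)cc2s1)c1cn(-c2ccccc2)nc1-c1ccccc1`: 17600 nM
Compound 3 `O=C(Nc1nc2ccc(Cl)cc2s1)c1cn(-c2ccccc2)nc1-c1ccccc1`: 21300 nM

Compound 1 stands at > 50000 nM, which is a limit and not a number. Compound 4 `O=C(Nc1nc2ccccc2s1)c1cn(-c2ccccc2)nc1-c1ccc(Cl)cc1` differs from it by one change, phenyl to 4-chlorophenyl: chloro in place of hydrogen on an aromatic carbon. The nearest evidence is an at least 2.3-fold lower number from compound 1 to compound 3 (0.37 log units; beyond the scatter), together with an at least 2.8-fold lower number from compound 1 to compound 2 (0.45 log units; beyond the scatter). Among the compounds with values here, both of those steps altered a different ring from the one that changes here, so they are only an indirect guide. A step of similar modest size toward a lower number is therefore expected in this assay. The estimated change is an at least 2.0-fold lower number from compound 1 to compound 4 (0.30 log units; that floor lies within the scatter). For compound 4 the expected value is 25000 nM, with an estimated range of 11000 nM to 50000 nM.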

Compound 4, half-maximal inhibitory concentration: 39600 nM
For compound 4 the middle estimate is 1.6-fold (0.20 log units) below the measured one; measured number inside the range.
By their numbers in this assay, from the lowest: compounds 2, 3 and 4 (each within the scatter of the next, the first and the last beyond it). At a limit, above all of these: compound 1.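

In this assay compound 1 stands at > 50000 nM as a limit and not a number. Chloro in place of hydrogen, para to a large group, gives an at least 1.2-fold lower number from compound 1 to compound 4 (0.10 log units; that floor lies within the scatter) as the only change shown on this ring. Unlike the steps on the other ring, whose floors lie beyond the scatter, this floor does not establish a real shift. As far as these compounds go, whether a fluoro, a methoxy or an amine at this position would move the number remains open. The true size of this step also stays open because only a floor can be given: the limit of > 50000 nM in this assay, at which 1 of the 4 values shown sits.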